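Ethoxy to methoxy in a quinoline amide series

The source may hold more compounds than are shown below. What is called first, only, known or untested is meant among the compounds shown, and "the series" means these compounds.

Measured so far:
compound 1, `Cc1ccc2nc(C(=O)Nc3c(F)cc(-c4cccc(F)c4)cc3F)c(C)c(O)c2c1`: 0.22%
compound 2, `CCc1ccc2nc(C(=O)Nc3c(F)cc(-c4cccc(F)c4)cc3F)c(C)c(O)c2c1`: 0.74%
compound 3, `CCOc1ccc2nc(C(=O)Nc3c(F)cc(-c4cccc(F)c4)cc3F)c(C)c(C(=O)O)c2c1`: -0.12%

These three compounds were tested in a functional assay on Hep 3B2 cells (Homo sapiens) for antiproliferative activity, read by MTT assay, with a stated time of 24 h, tested at 0.01 ug/mL; a higher number here means a stronger effect of the compound at the concentration tested, a lower number a weaker effect. All three numbers sit close to zero and within the scatter of one another, so none of them can be called more or less active than the others. Compound 2 and compound 1 differ in one place, (hydrogen in place of methyl on a saturated chain carbon bound to an aromatic carbon), and that step gave a number 0.5 percentage points lower from compound 2 to compound 1 (within the scatter). How the core of compound 3 differs from the core of compound 2 is not broken down here.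

Compound 4, `COc1ccc2nc(C(=O)Nc3c(F)cc(-c4cccc(F)c4)cc3F)c(C)c(C(=O)O)c2c1`, has not yet been measured. It differs from compound 3 by hydrogen in place of methyl on a saturated chain carbon bound to an oxygen on an aromatic ring. Among the compounds with values here, this is the same kind of change as the one from compound 2 to compound 1, though the place differs: there the carbon was bound to an aromatic carbon, here it is bound to an oxygen on an aromatic ring. Since that earlier step stayed within the scatter, the step from compound 3 to compound 4 is expected to be of the same small size, a number 0.3 percentage points higher from compound 3 to compound 4 (within the scatter), resting on the value of compound 3, -0.12%. The estimate for compound 4 is 0.2%, between -5% and 5%.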

Compound 4, a percentage reported as inhibition, at one concentration (the size of the read-out at that concentration, not a potency): -0.68%
Compound 4: the middle estimate sits 0.9 percentage points above what was measured; the measured number falls inside the stated range.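

In this assay, trimming the ethoxy group to methoxy gave a number 0.6 percentage points lower from compound 3 to compound 4 (within the scatter). The same swap of methyl for hydrogen on a saturated chain carbon has now been seen on two cores, and the two steps agree: the same change on two cores in this assay, a number 0.5 percentage points lower (within the scatter) from compound 2 to compound 1 and a number 0.6 percentage points lower (within the scatter) from compound 3 to compound 4, 0 percentage points apart, within the scatter of two such steps. This shows that the change left the read-out within the scatter on both cores, but both steps were read at a single concentration, with all the numbers close to zero, so it does not show that the change would stay this small on a compound with a clear effect.

The compounds shown also leave open whether a larger change at the same place, such as a longer chain like propoxy or an amine in place of the ethoxy group, would move the read-out beyond the scatter. As far as these compounds go, whether the two steps would still agree at a higher concentration also stays unknown.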